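The compounds below may be only part of what the source reports. "The series", "measured", "known", "first", "only" and "open" are said of these compounds alone.

Measured in a functional assay on SGC-7901 cells (Homo sapiens) for inhibition, read by MTT assay, with a stated time of 24 h; a higher number here means a weaker inhibitor, a lower number a stronger inhibitor:
- compound 1 `CC1(C)[C@H]2CC[C@]1(C)N(Cc1cn(-c3ccc(C#N)cc3)nn1)C(=O)C2`: 500 nM
- compound 2 `CC1(C)[C@H]2CC[C@]1(C)N(Cc1cn(-c3ccccc3Cl)nn1)C(=O)C2`: 220 nM

Among the compounds with values here, compound 2, at 220 nM, holds the lower of the two numbers so far, and compound 1 is its only neighbour. The next compound to be read is compound 3 `CC1(C)[C@H]2CC[C@]1(C)N(Cc1cn(-c3ccccc3)nn1)C(=O)C2`. The change is 2-chlorophenyl to phenyl: hydrogen in place of chloro on an aromatic carbon, ortho to a large group.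

Within the data shown here, one measured step bears on this change: a 2.3-fold lower number from compound 1 to compound 2 (0.36 log units; beyond the scatter). It is modest and concerns the same aryl group, but it replaces 4-cyanophenyl with 2-chlorophenyl, so it does not isolate the chloro. Among the measured compounds shown here, no measured pair shows the loss of chloro alone, and compound 3 carries neither substituent. A small step toward a higher number is therefore expected in this assay, no larger than the measured one and possibly within the scatter. The expected change is a 1.7-fold higher number from compound 2 to compound 3 (0.24 log units; within the scatter). With so little data the range is kept wide. Compound 3 is estimated at 380 nM, with an expected range of 150 nM to 900 nM.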

Compound 3, half-maximal inhibitory concentration: 240 nM
For compound 3 the middle estimate is 1.6-fold (0.20 log units) above the measured one; low and high end bracket the measured number.
By their numbers in this assay, from the lowest: compounds 2 and 3 (each within the scatter of the next); then compound 1.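

In this assay, hydrogen in place of chloro on an aromatic carbon, ortho to a large group, gives a 1.1-fold higher number from compound 2 to compound 3 (0.04 log units; within the scatter), so the chloro of compound 2 is not required to hold the number at this level, and the two compounds cannot be ordered. Hydrogen in place of cyano gives a 2.1-fold lower number from compound 1 to compound 3 (0.32 log units; beyond the scatter), which is beyond the scatter, so the earlier gap between the 4-cyanophenyl and 2-chlorophenyl compounds can now be read as following the cyano of compound 1 rather than the chloro of compound 2, though this rests on these three compounds alone. Nothing measured here offers a reason for either step.

Still open, going by these compounds, is whether an amine, a methoxy group or a carboxylic acid on the ortho carbon would stay level with compound 3 in this assay or move the number as the cyano does from its own place on the ring. Also open, on these data alone, is whether a chloro on the ring of 4-cyanophenyl's substituted carbon would match the cyano or the hydrogen, a comparison that would separate the identity of the group from its place.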